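This account rests on a few compounds, and the source may have more. Where it says the series, first, only, none or still open, it means among the compounds named here.

Compound 3, `C=CC1=C(C(=O)NCC(C)C)C(c2ccc(OC)cc2)OC1`, belongs to a small set built on a shared core. In a functional assay on SW480 cells (Homo sapiens) for cytotoxicity, read by MTT assay, with a stated time of 24 h (on this read-out higher numbers stand for weaker inhibition and lower numbers for stronger inhibition), compound 3 reaches only the limit of the assay, > 100000 nM. Compound 1, `C=CC1=C(C(=O)NC2CCCCC2)C(c2ccc(OC)cc2)OC1`, likewise gives only a limit, > 100000 nM. Compound 2, `C=CC1=C(C(=O)NCCCCC)C(c2ccc(OC)cc2)OC1`, also gives only a limit, > 100000 nM. Because (the limit of > 100000 nM in this assay, at which 3 of the 3 values shown sit), the steps a step that the two limits leave unreadable from compound 1 to compound 2, a step that the two limits leave unreadable from compound 1 to compound 3 and a step that the two limits leave unreadable from compound 2 to compound 3 cannot be sized. Compound 4, `C=CC1=C(C(=O)NCc2ccccc2F)C(c2ccc(OC)cc2)OC1`, differs from compound 3 by 2-fluorophenyl in place of isopropyl on a saturated chain carbon bound to an amide-type nitrogen. Going by the values given here, none of the measured steps brings in an aromatic ring at that place, so they show only that exchanging one alkyl group for another left every compound at the limit. The expected step is therefore a number no higher from compound 3 to compound 4 (the limit leaves the size open), with compound 4 most likely again at a limit. Compound 4 is estimated at 100000 nM, between 30000 nM and 300000 nM.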

Compound 4, half-maximal inhibitory concentration: > 100000 nM
Compound 4 gave a limit, no number; the forecaster's own chance of this, stated with the estimate: 70%; the middle value sits exactly at the limit.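

The steps from compound 1, compound 2 and compound 3 to compound 4 cannot be sized, because each compound gives only a limit: the limit of > 100000 nM in this assay, at which 4 of the 4 values shown sit. The compounds shown leave open whether any group on the amide-type nitrogen gives a readable number in this assay.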